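The source may hold more compounds than are shown below. What is called first, only, known or untested is meant among the compounds shown, and "the series" means these compounds.

In a functional assay on A549 cells (Homo sapiens) for cytotoxicity, read by MTT assay, with a stated time of 72 h (a lower number here means that less compound is needed, a higher number that more compound is needed for the effect), compound 1 `CCOC(=O)c1c(C)coc1-c1ccc2c(CC)cccc2c1OC` gives 3.8 ug/mL. Compound 2 `CCc1cccc2c(OC)c(-c3occ(C)c3C(=O)NC)ccc12` shows only a limit there, > 10 ug/mL, not a number. Compound 3 `CCc1cccc2c(OC)c(-c3occ(C)c3C(=O)On3nnc4ccccc43)ccc12` likewise sits at a limit, > 10 ug/mL. The step of an at least 2.6-fold higher number from compound 1 to compound 2 (0.42 log units; beyond the scatter) and the step of an at least 2.6-fold higher number from compound 1 to compound 3 (0.42 log units; beyond the scatter) both point the same way, while a step that the two limits leave unreadable from compound 2 to compound 3 because of the limit of > 10 ug/mL in this assay, at which 2 of the 3 values shown sit. Compound 4 `CCc1cccc2c(OC)c(-c3occ(C)c3COC(C)=O)ccc12` differs from compound 2 by acetoxymethyl in place of methylcarbamoyl on an aromatic carbon. Among the measured compounds shown here, no measured step mirrors this change; the two readable steps only show that leaving the ethyl ester of compound 1 raised the number. The expected outcome in this assay is therefore a step of an at least 1.2-fold lower number from compound 2 to compound 4 (0.09 log units; that floor lies within the scatter) that cannot be read, and compound 4 is estimated at 8 ug/mL, between 3 ug/mL and 20 ug/mL.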

Compound 4, concentration for half-maximal effect: > 10 ug/mL
Compound 4 was reported as a limit (the forecaster's own chance of this, stated with the estimate: 45%); middle value at least 1.2-fold (0.09 log units) from the limit.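

In this assay there is an at least 2.6-fold higher number from compound 1 to compound 4 (0.42 log units; beyond the scatter), so the number also rises when the carbonyl no longer sits directly on this aromatic carbon and the entering group has no hydrogen-bond donor. Compound 4 gives only a limit, > 10 ug/mL. The step between compound 2 and compound 4 cannot be read: the limit of > 10 ug/mL in this assay, at which 3 of the 4 values shown sit.

Going by these compounds, how a carboxylic acid, a hydroxymethyl group or a propyl ester would read on this carbon stays open. So does the true size of each step from compound 1.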